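The compounds below may be only part of what the source reports. "The series", "measured", "known", "first", "only" and "open" are said of these compounds alone.

Compound 1 `O=C(NN1CCOCC1)c1c(O)c2cccnc2n(-c2ccccc2)c1=O`: -8.5%
Compound 2 `Nc1ccc(NC(=O)c2c(O)c3cccnc3n(-c3ccccc3)c2=O)cc1`: -5.5%
Compound 3 `COc1ccccc1NC(=O)c1c(O)c2cccnc2n(-c2ccccc2)c1=O`: 8.1%

In a functional assay on the whole organism for inhibition, with Rattus norvegicus as the target, read by paw edema, at a dose of 100 mg/kg by the oral route (a lower number here means less inhibition, a higher number more inhibition at the dose given (going by the name of the read-out)), compound 3 gives 8.1%, the highest of the three numbers. Compound 2 gives -5.5% and compound 1 gives -8.5%. The steps of a number 13.6 percentage points higher from compound 2 to compound 3 (beyond the scatter) and a number 16.6 percentage points higher from compound 1 to compound 3 (beyond the scatter) are both beyond the scatter, whereas a number 3 percentage points higher from compound 1 to compound 2 (within the scatter) is within it, so only the 2-methoxyphenyl compound separates itself from the rest.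

Compound 4 `O=C(NCc1ccncc1)c1c(O)c2cccnc2n(-c2ccccc2)c1=O` differs from compound 3 in one place: (pyridin-4-yl)methyl in place of 2-methoxyphenyl on an amide-type nitrogen. Among the measured compounds shown here, no measured step exchanges an aryl group for an arylmethyl group on the amide-type nitrogen, so the change is new in kind. For the measured compounds named here, the steps that bear on it are a number 13.6 percentage points higher from compound 2 to compound 3 (beyond the scatter) and a number 16.6 percentage points higher from compound 1 to compound 3 (beyond the scatter), both modest, and both show that every substituent other than 2-methoxyphenyl gave a lower number. A modest downward step in this assay is therefore expected for compound 4, a number 10.1 percentage points lower from compound 3 to compound 4 (beyond the scatter), with the outcome most likely near the other two measured values. Compound 4 is estimated at -2%, within a range from -14% to 10%.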

Compound 4, a percentage reported as inhibition, in the whole organism at one dose (the size of the read-out at that dose, not a potency): 10%
For compound 4 the middle estimate is 12 percentage points below the measured one; the range from low to high includes it.
By their numbers in this assay, from the lowest: compounds 1 and 2 (each within the scatter of the next); then compounds 3 and 4 (each within the scatter of the next).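

In this assay, among the compounds shown here, the change from 2-methoxyphenyl to (pyridin-4-yl)methyl on the amide-type nitrogen gives a number 1.9 percentage points higher from compound 3 to compound 4 (within the scatter), so 2-methoxyphenyl is no longer the only group at this position that stands apart, and the other two steps agree: a number 15.5 percentage points higher from compound 2 to compound 4 (beyond the scatter) and a number 18.5 percentage points higher from compound 1 to compound 4 (beyond the scatter). An aromatic ring on or near this nitrogen does not settle the result, however: compound 2 also carries one, and the step to it is a number 3 percentage points higher from compound 1 to compound 2 (within the scatter). Nothing measured here explains why these groups differ.

Going by these compounds, it remains open whether a benzyl group or a 2-(pyridin-4-yl)ethyl chain on this nitrogen would stay level with compound 3 and compound 4. These readings at a single dose also leave open how the compounds would compare across a range of doses.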